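The source may report more compounds than this note shows. Statements on the series, on what has been measured and on what is new or still open speak of the compounds shown alone.

Measured compounds:
Compound 1, `ClCc1ccc(Cn2cnc3c(Cl)ncnc32)cc1`, gives 1310 nM.
Compound 2, `Nc1nc(Cl)c2ncn(Cc3cccc(CCl)c3)c2n1`, gives 4260 nM.
Compound 3, `ClCc1ccc(Cn2cnc3ncnc(Cl)c32)cc1`, gives "not determined" (no result reported).

These values come from a functional assay on DU-145 cells (Homo sapiens) for cytotoxicity, read by sulforhodamine B assay, with a stated time of 48 h; on this read-out higher numbers stand for weaker inhibition of growth and lower numbers for stronger inhibition of growth. Compound 1 and compound 2 each have a number there, and compound 2 sits at a higher number than compound 1. Compound 3 has no single number on this read-out, so where it stands among the others cannot be said from the data.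

Compound 4, `ClCc1ccc(Cn2cnc3nc(Cl)nc(Cl)c32)cc1`, is reached from compound 3 by a single change:
chloro in place of hydrogen on an aromatic carbon
The change puts a chloro group on an aromatic carbon of the shared core, with everything else unchanged.

For the measured compounds named here, no measured pair shows what such a change does in this assay, so no measured step can be quoted. Going by the values given here, since compound 3 itself has no number, the only guide is that compound 1 and compound 2, which share the chloromethyl-benzyl arm and a chlorinated core, both fall in the low-micromolar range, with compound 1 at 1310 nM and compound 2 at 4260 nM. A step of no more than the scatter in either direction is expected. Compound 4 is therefore estimated at 1500 nM, within a range from 500 nM to 5000 nM.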

Compound 4, concentration for 50% growth inhibition: 1810 nM
The estimate for compound 4 lay 1.2-fold (0.08 log units) below the measured number; the range from low to high includes it.
By their numbers in this assay, from the lowest: compounds 1 and 4 (each within the scatter of the next); then compound 2.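

Compound 3 has no number to set against compound 4 at 1810 nM, so no step can be read from this result. Nothing available offers an explanation for this value. Going by these compounds, what a chloro group in place of hydrogen on this aromatic carbon does to growth inhibition stays open.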